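The source may report more compounds than this note shows. Statements on the series, on what has been measured and on what is new or still open speak of the compounds shown alone.

Compound 1 `COc1ccccc1-c1nnc(-c2ccc(C(=O)N/N=C/c3ccc(O)c(O)c3)cc2)o1` gives 100000 nM in an ADME assay on THP-1 cells (Homo sapiens) for cytotoxicity; a higher number here means a weaker inhibitor, a lower number a stronger inhibitor. For the measured compounds named here, compound 2 `COc1ccccc1-c1nnc(-c2ccc(C(=O)N/N=C/c3ccccc3F)cc2)o1` gives 313000 nM, the highest of the two numbers recorded; its only neighbour is compound 1, and the change of a 3.1-fold higher number from compound 1 to compound 2 (0.50 log units; beyond the scatter) separates them. Compound 3 `COc1ccccc1-c1nnc(-c2ccc(C(=O)N/N=C/c3c(O)cc(O)cc3O)cc2)o1` is then made from compound 2 by 2,4,6-trihydroxyphenyl in place of 2-fluorophenyl on a carbon with a double bond to nitrogen. Going by the values given here, the one step that bears on this, a 3.1-fold higher number from compound 1 to compound 2 (0.50 log units; beyond the scatter), ran the opposite way, from a hydroxylated ring to the fluorinated one, so the return to a hydroxylated ring is expected to lower the number by a modest amount, about a 2.6-fold lower number from compound 2 to compound 3 (0.42 log units; beyond the scatter). Compound 3 is therefore estimated at 120000 nM, within 50000 nM to 300000 nM.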

Compound 3, half-maximal inhibitory concentration: 12400 nM
Beside the measured number, compound 3's estimate is 9.7-fold (0.99 log units) above it, outside the stated range (below it).
By their numbers in this assay, from the lowest: compound 3; then compound 1; then compound 2.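

In this assay the group on a carbon with a double bond to nitrogen moves the number much further than the earlier step showed, and a 25-fold lower number from compound 2 to compound 3 (1.40 log units; beyond the scatter) is a large change. The two hydroxylated rings are not equivalent either: an 8.1-fold lower number from compound 1 to compound 3 (0.91 log units; beyond the scatter) separates the 3,4-dihydroxyphenyl group from the 2,4,6-trihydroxyphenyl group. Nothing on hand explains these differences. The compounds shown leave open whether the count of hydroxyl groups or their placing matters more, and how a ring carrying an amine or a carboxylic acid would compare.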